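The source may hold more compounds than are shown below. What is called first, only, known or untested is meant among the compounds shown, and "the series" means these compounds.

Measured so far in an ADME assay on HepG2 2.2.15 cells (Homo sapiens) for cytotoxicity; on this read-out lower numbers stand for higher toxicity in this test and higher numbers for lower toxicity in this test:
Compound 1 `CC(C)C(=O)OCCc1c(-c2ccccc2Cl)c2cc(Cl)ccc2[nH]c1=O` gives 62000 nM
Compound 2 `O=C(/C=C/c1ccccc1)OCCc1c(-c2ccccc2Cl)c2cc(Cl)ccc2[nH]c1=O` gives 230000 nM

Compound 2 stands highest of the two. Compound 3 `COc1ccc(/C=C/C(=O)OCCc2c(-c3ccccc3Cl)c3cc(Cl)ccc3[nH]c2=O)cc1` differs from it by one change, (methoxy in place of hydrogen on an aromatic carbon), turning phenyl to 4-methoxyphenyl. Among the measured compounds shown here, the only measured step, a 3.7-fold higher number from compound 1 to compound 2 (0.57 log units; beyond the scatter), is 2-phenylethenyl in place of isopropyl on a carbonyl carbon. It was modest and did not test any group on this aromatic ring, so no step beyond the scatter is expected in this assay, in either direction. The expected step is a 1.2-fold lower number from compound 2 to compound 3 (0.06 log units; within the scatter), with no firm direction. Compound 3 is estimated at 200000 nM (expected range 90000 nM to 450000 nM)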

Compound 3, half-maximal cytotoxic concentration: > 1200000 nM
Compound 3: a limit, no number (the forecaster's own chance of this, stated with the estimate: 15%); middle value at least 6.0-fold (0.77 log units) away from the limit.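

In this assay, the aromatic ring of the 2-phenylethenyl group proves sensitive to a single change: methoxy in place of hydrogen, para to a large group, gives an at least 5.2-fold higher number from compound 2 to compound 3 (0.71 log units; beyond the scatter). Compound 3 gives > 1200000 nM, which is a limit of the assay and not a number. Replacing isopropyl with 2-(4-methoxyphenyl)ethenyl gives an at least 19-fold higher number from compound 1 to compound 3 (1.28 log units; beyond the scatter), so the methoxy group extends the rise seen with the 2-phenylethenyl group.

From the compounds shown here alone, the true value of compound 3 remains unknown, and so does the full size of both steps. Going by these compounds, it also remains open whether a hydroxy group, an amine or a chlorine on this ring would move the number the same way.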